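A few compounds are considered here, and "the series" means these few. Any claim that something is new, unique, unknown or untested is made for them only; others in the source may bear on it.

Measured compounds:
- compound 1 `O=C(O)CCCCCCC(=O)Nc1ccc(C2=C(c3ccc(O)cc3)C3CC(S(=O)(=O)Oc4ccc(F)cc4)C2O3)cc1`: 24800 nM
- compound 2 `O=C(O)CCCCCCC(=O)Nc1cccc(OS(=O)(=O)C2CC3OC2C(c2ccc(O)cc2)=C3c2ccc(O)cc2)c1`: limit, > 100000 nM
- compound 3 `O=C(O)CCCCCCC(=O)Nc1ccc(OS(=O)(=O)C2CC3OC2C(c2ccc(O)cc2)=C3c2ccc(O)cc2)cc1`: 19100 nM

In a functional assay on MCF7 cells (Homo sapiens) for inhibition, read by MTT assay, with a stated time of 72 h (a lower number here means a stronger inhibitor, a higher number a weaker inhibitor), compound 1 gives 24800 nM. This is the highest of the two numbers reported; the nearest is compound 3, which in this assay gives 19100 nM, a gap that lies within the scatter, so no order between compound 1 and compound 3 is claimed. For compound 2 this assay reports only a limit, > 100000 nM, as noted in the limit of > 100000 nM in this assay, at which 1 of the 3 values shown sits, and no number.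

Compound 4 `Cc1ccc(OS(=O)(=O)C2CC3OC2C(c2ccc(NC(=O)CCCCCCC(=O)O)cc2)=C3c2ccc(O)cc2)cc1` has not yet been measured in this assay. It differs from compound 1 in one place: methyl in place of fluoro on an aromatic carbon. Among the measured compounds shown here, no measured pair in this set shows such a change, so the size of the step is open. A small substituent swap of this kind, far from the shared core, is expected to move the number little, and no step beyond the scatter is expected in either direction. Compound 4 is therefore estimated at 25000 nM, with a range of 10000 nM to 65000 nM, meaning an expected step of a 1.0-fold higher number from compound 1 to compound 4 (0.00 log units; within the scatter) that stays within the scatter.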

Compound 4, half-maximal inhibitory concentration: 60500 nM
Beside the measured number, compound 4's estimate is 2.4-fold (0.38 log units) below it, within the range that was stated.
By their numbers in this assay, from the lowest: compounds 3 and 1 (each within the scatter of the next); then compound 4. At a limit, above all of these: compound 2.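

The step of a 2.4-fold higher number from compound 1 to compound 4 (0.39 log units; beyond the scatter) in this assay is the only one in this set that can be read between compounds differing in one place. It shows that this position, on an aromatic carbon para to a large group, responds to the exchange of a single heavy atom, even though fluoro and methyl match in the counts of hydrogen-bond donors, acceptors and net charge. Nothing measured here accounts for this modest step.

On these data alone, with only fluoro and methyl compared at this position, it remains open how a chloro group, a methoxy group or an amine would read there. The compounds shown also leave open whether the same change would give a step of similar size on a different core.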